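From Hydroxymethyl to Butyl on a Shared Core

The source may report more compounds than this note shows. Statements on the series, on what has been measured and on what is new or still open speak of the compounds shown alone.

Going by the values given here, in a functional assay on HeLa cells (Homo sapiens) for antiproliferative activity, read by sulforhodamine B assay, with a stated time of 48 h (on this read-out higher numbers stand for weaker inhibition of growth and lower numbers for stronger inhibition of growth), compound 1 (`Cc1ccc(-c2cn(CCCN3C(=O)COc4ccccc43)nn2)cc1`) gives 14300 nM and compound 2 (`O=C1COc2ccccc2N1CCCn1cc(CO)nn1`) gives 7300 nM so compound 2 stands level with its only measured neighbour. Compound 3 (`CCCCc1cn(CCCN2C(=O)COc3ccccc32)nn1`) differs from compound 2 by propyl in place of hydroxy on a saturated chain carbon bound to an aromatic carbon with propyl in place of hydroxy on a saturated chain carbon bound to an aromatic carbon. Among the compounds with values here, one measured step bears on this: at the same group, a 2.0-fold lower number from compound 1 to compound 2 (0.29 log units; within the scatter) stayed within the scatter. The expected size in this assay is therefore nothing beyond the scatter, an estimated 1.2-fold higher number from compound 2 to compound 3 (0.09 log units; within the scatter) at most. The estimate for compound 3 is 9000 nM (3500 nM to 22000 nM).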

Compound 3, concentration for 50% growth inhibition: 1020 nM
Estimate against measurement, compound 3: 8.8-fold (0.95 log units) above; the whole stated range lies above it.
By their numbers in this assay, from the lowest: compound 3; then compounds 2 and 1 (each within the scatter of the next).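

In this assay this position proves responsive to the group it carries: hydroxymethyl to butyl gives a 7.2-fold lower number from compound 2 to compound 3 (0.85 log units; beyond the scatter) while the earlier change stayed within the scatter. Butyl in place of 4-methylphenyl gives a 14-fold lower number from compound 1 to compound 3 (1.15 log units; beyond the scatter) as well, which makes compound 3 the most potent of the three. No measurement at hand explains this gain.

From the compounds shown here alone, whether a longer chain such as hexyl or a shorter one such as ethyl would do better or worse remains open. So does whether an amine on this chain would keep the gain.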